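Moving the fluoro group from 4-fluorophenyl to 2-fluorophenyl

The compounds below may be only part of what the source reports. "The series", "measured", "known", "first", "only" and "open" are said of these compounds alone.

Compound 1 `C=C1C(=O)[C@@]23C(=O)OC[C@]4(C(=O)CCC(C)(C)[C@H]4C=O)[C@@H]2CC[C@@H]1[C@H]3OC(=O)c1ccc(OC)cc1` gives 2800 nM
Compound 2 `C=C1C(=O)[C@@]23C(=O)OC[C@]4(C(=O)CCC(C)(C)[C@H]4C=O)[C@@H]2CC[C@@H]1[C@H]3OC(=O)c1ccc([N+](=O)[O-])cc1` gives 3300 nM
Compound 3 `C=C1C(=O)[C@@]23C(=O)OC[C@]4(C(=O)CCC(C)(C)[C@H]4C=O)[C@@H]2CC[C@@H]1[C@H]3OC(=O)c1ccc(F)cc1` gives 3750 nM

These three values come from a functional assay on Bel-7402 cells (Homo sapiens) for cytotoxicity, read by MTT assay, with a stated time of 72 h (a lower number here means a stronger inhibitor, a higher number a weaker inhibitor), and the three compounds differ in one group on an aromatic carbon. Compound 3 stands level with the other two, as its measured steps show: a 1.3-fold higher number from compound 1 to compound 3 (0.13 log units; within the scatter) and a 1.1-fold higher number from compound 2 to compound 3 (0.06 log units; within the scatter) are both small, and neither separates it from its neighbours.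

The change to compound 4 `C=C1C(=O)[C@@]23C(=O)OC[C@]4(C(=O)CCC(C)(C)[C@H]4C=O)[C@@H]2CC[C@@H]1[C@H]3OC(=O)c1ccccc1F` is 2-fluorophenyl in place of 4-fluorophenyl on a carbonyl carbon and it puts 2-fluorophenyl in place of 4-fluorophenyl on a carbonyl carbon. Within the data shown here, no measured step makes this same change, so the data give no direct measure of it. The nearest evidence is the set of group exchanges among the three measured compounds. Besides the two steps to compound 3, this set holds a 1.2-fold higher number from compound 1 to compound 2 (0.07 log units; within the scatter) and it too stays within the scatter. Methoxy, nitro and fluoro thus gave no separable values in these three compounds.

On that basis, no step beyond the scatter is expected, and no direction is favoured. The expected step is a 1.1-fold lower number from compound 3 to compound 4 (0.06 log units; within the scatter) on this estimate. Compound 4 is estimated at 3300 nM with an expected range from 1700 nM to 6500 nM in this assay when it is measured.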

Compound 4, half-maximal inhibitory concentration: 3950 nM
Compound 4: the middle estimate sits 1.2-fold (0.08 log units) below what was measured, and the stated range covers the measured number.
By their numbers in this assay, from the lowest: compounds 1, 2, 3 and 4 (each within the scatter of the next).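

In this assay, among these compounds, moving the fluoro group gives a 1.1-fold higher number from compound 3 to compound 4 (0.02 log units; within the scatter), the only step here that changes where a group sits on the aromatic ring rather than which group sits there, and 2-fluorophenyl on the carbonyl carbon cannot be told apart from 4-fluorophenyl. The same holds when 2-fluorophenyl is set against the other two groups, with a 1.2-fold higher number from compound 2 to compound 4 (0.08 log units; within the scatter) and a 1.4-fold higher number from compound 1 to compound 4 (0.15 log units; within the scatter), so the four compounds form one level set in which neither the identity of the group nor this change of its place gives a separable value. Nothing measured here bears on why these exchanges leave the number unchanged within the scatter.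

On these data alone, whether this level picture would hold for an amine or a carboxylic acid on the aromatic ring, or for a longer chain in place of the ring on the carbonyl carbon, remains open. All four compounds also keep the same core, so what a change to the core would do to the number in this assay is left open as well.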